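The source may report more compounds than this note shows. Statements on the series, on what has been measured and on what is new or still open speak of the compounds shown alone.

Measured in a functional assay on HT-29 cells (Homo sapiens) for antiproliferative activity, read by sulforhodamine B assay, with a stated time of 48 h; on this read-out lower numbers stand for stronger inhibition and higher numbers for weaker inhibition:
- compound 1 `CCCN1CCN(c2ccc(S(=O)(=O)Oc3ccccc3OC)cc2)C1=O`: > 100000 nM, a limit and not a number
- compound 2 `CCCN1CCN(c2ccc(S(=O)(=O)Oc3cccc([N+](=O)[O-])c3)cc2)C1=O`: > 100000 nM, a limit and not a number
- compound 3 `CCCN1CCN(c2ccc(S(=O)(=O)Oc3ccc(C)cc3)cc2)C1=O`: 25000 nM

Among the compounds with values here, compound 3, at 25000 nM, is the only compound here with a true number. The reference point for the others is the limit of > 100000 nM in this assay, at which 2 of the 3 values shown sit.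

Compound 4 `CCCN1CCN(c2ccc(S(=O)(=O)Oc3ccc(F)cc3)cc2)C1=O` keeps the shared core and differs from compound 3 in one place: fluoro in place of methyl on an aromatic carbon, para to a large group. The nearest evidence comes from changes of the group on the same oxygen: an at least 4.0-fold lower number from compound 1 to compound 3 (0.60 log units; beyond the scatter) and an at least 4.0-fold lower number from compound 2 to compound 3 (0.60 log units; beyond the scatter). Both give only a minimum size, and neither replaces the methyl itself. The remaining comparison is unreadable: a step that the two limits leave unreadable from compound 1 to compound 2.

With compound 3 at 25000 nM as the sole anchor, the expected step is small and leans toward a higher number: a 1.4-fold higher number from compound 3 to compound 4 (0.15 log units; within the scatter). Compound 4 is expected at 35000 nM, with an estimated range of 12000 nM to 100000 nM.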

Compound 4, half-maximal inhibitory concentration: 23000 nM
Estimate against measurement, compound 4: 1.5-fold (0.18 log units) above; measured number inside the range.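

Within the data shown here, on the aromatic carbon para to a large group, methyl to fluoro gives the first step at this position with a true number at both ends: in this assay there is a 1.1-fold lower number from compound 3 to compound 4 (0.04 log units; within the scatter), so the two groups cannot be told apart here. The 4-fluorophenyl group also stands clear of the other two groups on the same oxygen, with an at least 4.3-fold lower number from compound 2 to compound 4 (0.63 log units; beyond the scatter) and an at least 4.3-fold lower number from compound 1 to compound 4 (0.63 log units; beyond the scatter). Both of these steps give only a minimum size, as compound 1 and compound 2 rest on a limit: the limit of > 100000 nM in this assay, at which 2 of the 4 values shown sit.

As far as these compounds go, whether an amine, a carboxylic acid or a longer chain in place of the fluoro would shift the number stays open. Also open, from the compounds shown here alone, is what sets compound 1 and compound 2 apart from compound 3 and compound 4, the group itself or where it sits.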